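A few compounds are considered here, and "the series" means these few. Any claim that something is new, unique, unknown or untested is made for them only; others in the source may bear on it.

Working notes on the series. Within the data shown here, in a functional assay (spleen, spleen) for activation, with Mus musculus as the target (on this read-out higher numbers stand for an effect only at larger amounts of compound and lower numbers for an effect already at smaller amounts), compound 1 `CCNc1nc(N)c2nc(O)n(Cc3ccccc3)c2n1` gives 1 uM, which is the only number in hand. Compound 2 `Nc1ncnc2c1nc(Cl)n2Cc1ccccc1` reaches only a limit in this assay, > 10 uM, and the limit itself is the limit of > 10 uM in this assay, at which 1 of the 2 values shown sits. Among the measured compounds shown here, no step between two measured compounds that differ in a single place is available, so nothing measured yet tells how large a change at this position moves the minimum effective concentration.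

Compound 3 `CSc1nc(N)c2nc(O)n(Cc3ccccc3)c2n1` has not yet been tested in this assay. It differs from compound 1 by methylsulfanyl in place of ethylamino on an aromatic carbon. The group that leaves carries a hydrogen-bond donor, the group that enters carries none. The step is expected to be a 3.0-fold higher number from compound 1 to compound 3 (0.48 log units; beyond the scatter), a modest rise in the minimum effective concentration, somewhat beyond the usual scatter. Compound 3 is estimated at 3 uM, with a range from 1 uM to 10 uM.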

Compound 3, minimum effective concentration: 0.1 uM
Estimate against measurement, compound 3: 30-fold (1.48 log units) above, and the stated range ends above it.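

Methylsulfanyl in place of ethylamino gives the first measured step at this position in this assay (a 10-fold lower number from compound 1 to compound 3 (1.00 log units; beyond the scatter)), so this aromatic carbon between two ring nitrogen atoms is one where a single exchange moves the read-out beyond the scatter. The direction is toward an effect at smaller amounts, and the entering group carries no hydrogen-bond donor, so a donor on this substituent is not required for activity in compound 3. No measured property in hand bears on this step.

The compounds shown leave open whether the lower number follows the sulfur atom or the missing donor, a question that methoxy on the same carbon could address. From the compounds shown here alone, whether a longer chain on sulfur, such as butylsulfanyl, keeps the effect at smaller amounts also remains open.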